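The source may report more compounds than this note shows. Statements on the series, on what has been measured and on what is new or still open speak of the compounds shown alone.

The three measured compounds share one core and differ only in the group carried on the sulfur. Compound 1 `Cc1cc(N2CC[C@@H](C)[C@@H](N(C)c3ncnc4[nH]ccc34)C2)n2nc(SCC3CC3)nc2n1` carries cyclopropyl on the saturated chain carbon bound to that sulfur, and in a toxicity assay on GES1 cells (Homo sapiens) for inhibition, read by MTT assay, with a stated time of 72 h (on this read-out lower numbers stand for stronger inhibition and higher numbers for weaker inhibition), compound 1 gives 27900 nM. Compound 3 `Cc1cc(N2CC[C@@H](C)[C@@H](N(C)c3ncnc4[nH]ccc34)C2)n2nc(SCc3cc(Cl)ccc3Cl)nc2n1` carries 2,5-dichlorophenyl in the same place, and in this assay compound 3 gives 87500 nM. Compound 2 `Cc1cc(N2CC[C@@H](C)[C@@H](N(C)c3ncnc4[nH]ccc34)C2)n2nc(SCc3csc4ccc(Cl)cc34)nc2n1` carries 5-chloro-1-benzothiophen-3-yl there. In this assay compound 2 reaches only a limit of the assay, > 100000 nM, so no number is known for it (the limit of > 100000 nM in this assay, at which 1 of the 3 values shown sits). Both steps from the small cyclopropyl to a larger aromatic group went upward: an at least 3.5-fold higher number from compound 1 to compound 2 (0.55 log units; beyond the scatter) and a 3.1-fold higher number from compound 1 to compound 3 (0.50 log units; beyond the scatter). The two aromatic groups themselves cannot be separated, as an at least 1.1-fold lower number from compound 2 to compound 3 (0.05 log units; that floor lies within the scatter).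

Compound 4 `C#CSc1nc2nc(C)cc(N3CC[C@@H](C)[C@@H](N(C)c4ncnc5[nH]ccc45)C3)n2n1` differs from compound 2 in this way: ethynyl in place of (5-chloro-1-benzothiophen-3-yl)methyl on a sulfur. The (5-chloro-1-benzothiophen-3-yl)methyl group that leaves is the largest in the set, and the ethynyl that enters is smaller than cyclopropyl. The measured steps bear on this change in reverse: removing bulk at this sulfur has twice gone with a lower number. A downward step is therefore expected, an at least 3.3-fold lower number from compound 2 to compound 4 (0.52 log units; beyond the scatter), although the assay may again report only a limit. Compound 4 is estimated at 30000 nM, between 10000 nM and 100000 nM.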

Compound 4, half-maximal inhibitory concentration: > 100000 nM
Compound 4: no number, only a limit (the forecaster's own chance of this, stated with the estimate: 25%); middle value at least 3.3-fold (0.52 log units) away from the limit.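

Compound 4 carries the smallest group seen on this sulfur, and like compound 2 it stands only at a limit of the assay: the limit of > 100000 nM in this assay, at which 2 of the 4 values shown sit. The link between less bulk and a lower number, drawn from compound 1, compound 2 and compound 3, therefore does not hold, and compound 4 goes against it: in this assay there is an at least 3.5-fold higher number from compound 1 to compound 4 (0.55 log units; beyond the scatter), so ethynyl in place of cyclopropylmethyl moves the read-out upward, not downward. Against the 2,5-dichlorobenzyl group there is an at least 1.1-fold higher number from compound 3 to compound 4 (0.05 log units; that floor lies within the scatter), which does not separate the two compounds, and the step between compound 2 and compound 4 cannot be read, with a limit on each side.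

Among these four compounds, cyclopropylmethyl alone stands clearly lower, and the shown values cannot tell whether that reflects something particular to this group or merely how few groups have been compared. Also open, as far as these compounds go, is where a plain methyl, a longer alkyl chain, or a chain ending in an amine or a carboxylic acid on this sulfur would fall relative to compound 1, and how far compound 2 and compound 4 truly lie beyond their limit.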